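Swapping the pendant ring on a shared sulfonamide core

This account rests on a few compounds, and the source may have more. Where it says the series, first, only, none or still open, it means among the compounds named here.

Compound 1 `COc1ccccc1C1C(C#N)=C(N)N(c2ccc(S(N)(=O)=O)cc2)C2=C1CCCC2` carries a 2-methoxyphenyl group on a saturated ring carbon of its core. In a functional assay on Ehrlich cells (Mus musculus) for cytotoxicity, read by trypan blue exclusion, with a stated time of 2 h, tested at 100 ug/mL (on this read-out lower numbers stand for a weaker effect and higher numbers for a stronger effect at the one concentration tested), compound 1 gives 100%, the highest of the three numbers seen so far. Compound 2 `N#CC1=C(N)N(c2ccc(S(N)(=O)=O)cc2)C2=C(CCCC2)C1c1cccc([N+](=O)[O-])c1` gives 12% and compound 3 `N#CC1=C(N)N(c2ccc(S(N)(=O)=O)cc2)C2=C(CCCC2)C1c1ccc([N+](=O)[O-])cc1` gives 20% in this assay. Both measured changes start from compound 1: a number 88 percentage points lower from compound 1 to compound 2 (beyond the scatter) and a number 80 percentage points lower from compound 1 to compound 3 (beyond the scatter). Between the two nitro compounds, a number 8 percentage points higher from compound 2 to compound 3 (within the scatter).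

Compound 4 `N#CC1=C(N)N(c2ccc(S(N)(=O)=O)cc2)C2=C(CCCC2)C1c1ccc(Cl)cc1Cl` has not been measured. Its change from compound 1 is 2,4-dichlorophenyl in place of 2-methoxyphenyl on a saturated ring carbon. Within the data shown here, no measured step involves a 2,4-dichlorophenyl group, so the only guide is that both exchanges of the 2-methoxyphenyl group tried so far led to large losses. A drop is therefore expected, though its size is uncertain. The range is kept wide. For compound 4 in this assay the expected value is 40%, spanning from 10% to 95%, meaning an expected a number 60 percentage points lower from compound 1 to compound 4 (beyond the scatter).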

Compound 4, a percentage reported as activity, at one concentration (the size of the read-out at that concentration, not a potency): 70%
The estimate for compound 4 lay 30 percentage points below the measured number; the measured number falls inside the stated range.
By their numbers in this assay, from the lowest: compounds 2 and 3 (each within the scatter of the next); then compound 4; then compound 1.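

In this assay, the saturated ring carbon turns out not to punish every exchange of the 2-methoxyphenyl group: the 2,4-dichlorophenyl group brings a modest drop (a number 30 percentage points lower from compound 1 to compound 4 (beyond the scatter)), far smaller than the drops seen with either nitrophenyl group. It also stands well clear of both nitro compounds (a number 50 percentage points higher from compound 3 to compound 4 (beyond the scatter); a number 58 percentage points higher from compound 2 to compound 4 (beyond the scatter)), so this position separates one replacement ring from another instead of treating them all alike. Nothing measured here accounts for the difference between these rings.

Which of the two chlorine atoms matters remains open, as neither a 2-chlorophenyl nor a 4-chlorophenyl group appears among the compounds shown. How a plain phenyl ring, or a phenyl ring bearing an amine or a carboxylic acid, would behave at this carbon is also unknown.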